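The compounds below may be only part of what the source reports. "The series", "measured", "known", "first", "only" and "open" are said of these compounds alone.

Compound 2, `COc1ccc(C2=C(c3cc(OC)c(OC)c(OC)c3)C(=O)CC2O[SiH2]C(C)(C)C)cc1OC`, carries a 3,4-dimethoxyphenyl group on the shared core, the same core that compound 1, `COc1ccc(C2=C(c3cc(OC)c(OC)c(OC)c3)C(=O)C(OC(C)=O)C2)cc1F`, and compound 3, `COc1ccc(C2=C(c3cc(OC)c(OC)c(OC)c3)C(=O)C(O[SiH2]C(C)(C)C)C2)cc1OC(C)C`, bear with other substitution. In an ADME assay on ECV-304 cells (Homo sapiens) for cytotoxicity, read by MTT assay, with a stated time of 72 h (a higher number here means a weaker inhibitor, a lower number a stronger inhibitor), compound 1 gives 41 ug/mL. For compound 2 the read-out is only a limit of the assay, > 100 ug/mL. For compound 3 the read-out is likewise a limit, > 100 ug/mL. Among the compounds with values here, compound 2 thus has no number of its own, and no measured step leads away from it.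

Compound 4, `COC(=O)c1cc(C2=C(c3cc(OC)c(OC)c(OC)c3)C(=O)CC2O[SiH2]C(C)(C)C)ccc1OC`, differs from compound 2 in one place: methoxycarbonyl in place of methoxy on an aromatic carbon. Read one bond further out, the difference is 3,4-dimethoxyphenyl to 4-methoxy-3-(methoxycarbonyl)phenyl. Within the data shown here, no pair of measured compounds shows this change, so nothing here tells its size or direction.

The expectation for compound 4 in this assay rests on (the limit of > 100 ug/mL in this assay, at which 2 of the 3 values shown sit), where compound 2 already sits: a weak effect again, with no step beyond the scatter. Compound 4 is expected to give about 90 ug/mL, between 40 ug/mL and 200 ug/mL. The expected step is an at least 1.1-fold lower number from compound 2 to compound 4 (0.04 log units; that floor lies within the scatter), and a reading that is again only a limit is quite likely.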

Compound 4, half-maximal inhibitory concentration: > 100 ug/mL
Compound 4: no number, only a limit (the forecaster's own chance of this, stated with the estimate: 60%); at least 1.1-fold (0.04 log units) between middle value and limit.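

Compound 2 and compound 4 both read only as limits of the assay, and the step between them cannot be read. The compounds shown leave open whether methoxycarbonyl in place of methoxy on an aromatic carbon changes the read-out in this assay at all, and if it does, in which direction and by how much.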